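Bromoisoxazoline amino acid series: cytotoxicity notes

The source may report more compounds than this note shows. Statements on the series, on what has been measured and on what is new or still open speak of the compounds shown alone.

The series shares a bromo-substituted isoxazoline core carrying an amino-bearing side chain; the members differ in what is attached to the amine-bearing carbon. Compound 1 `N[C@H](CS(=O)(=O)Cc1ccccc1)[C@H]1CC(Br)=NO1` carries a benzyl sulfone, compound 2 `COC(=O)[C@@H](N)[C@@H]1CC(Br)=NO1` a methyl ester, compound 3 `N[C@H](C(=O)NCc1ccc(F)cc1)[C@@H]1CC(Br)=NO1` a fluorobenzyl amide, and compound 4 `N[C@H](C(=O)NCc1ccccc1)[C@@H]1CC(Br)=NO1` a benzyl amide.

Among the measured compounds shown here, in an ADME assay on HMEC-1 cells (Homo sapiens) for cytotoxicity, read by MTT assay, with a stated time of 72 h (on this read-out lower numbers stand for stronger inhibition and higher numbers for weaker inhibition), only one number is available: compound 2 gives 34800 nM. Compound 1 has no result in this assay, its entry reading "not determined" (no result reported). Compound 3 likewise has no number, its entry reading "not determined" (no result reported), so compound 3 cannot be placed against compound 2 on the numbers shown; two of the three measured entries lack a value.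

The change from compound 3 to compound 4 is hydrogen in place of fluoro on an aromatic carbon. For the measured compounds named here, no step between two measured compounds exists to calibrate the effect of such a change on this read-out. With nothing to the contrary, the expectation is that the step from compound 3 to compound 4 stays within the usual scatter, with no direction beyond it.

Compound 4 is therefore expected to give roughly 30000 nM in this assay, with a range from 8000 nM to 100000 nM, anchored on the weak cytotoxicity of compound 2 at 34800 nM.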

Compound 4, half-maximal inhibitory concentration: 14900 nM
The estimate for compound 4 lay 2.0-fold (0.30 log units) above the measured number, within the range that was stated.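

In this assay, among the compounds shown here, compound 4 gives 14900 nM, but compound 3 has no single number there, so no step between compound 3 and compound 4 can be read. No supporting data bear on this result. The compounds shown leave open what hydrogen in place of fluoro on the aromatic carbon does to this cytotoxicity read-out.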